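Extending the Amine Substituent from Cyclobutyl to Hexyl

The compounds below may be only part of what the source reports. "The series", "measured", "known", "first", "only" and "open" are said of these compounds alone.

Two compounds share a common core and differ only in the group carried on a nitrogen on an aromatic ring. Compound 1 `Clc1ccccc1Cn1nnc2c(NC3CC3)nc(-c3ccccc3)nc21` carries a cyclopropyl there, and in an assay on isolated protein for binding affinity to adenosine receptor A1 (Bos taurus) (a higher number here means a weaker inhibitor, a lower number a stronger inhibitor), compound 1 gives 11000000 nM. Compound 2 `Clc1ccccc1Cn1nnc2c(NC3CCC3)nc(-c3ccccc3)nc21` carries a cyclobutyl, and in this assay compound 2 gives 24000000 nM. The step between them, a 2.2-fold higher number from compound 1 to compound 2 (0.34 log units; beyond the scatter), is modest but beyond the scatter. On the two numbers available, compound 2 stands with the highest value, its nearest neighbour being compound 1.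

Compound 3 `CCCCCCNc1nc(-c2ccccc2)nc2c1nnn2Cc1ccccc1Cl` has not yet been measured. It differs from compound 2 as follows: hexyl in place of cyclobutyl on a nitrogen on an aromatic ring. Going by the values given here, only one measured step bears on this change, the enlargement of the ring from compound 1 to compound 2, and it moved the number only modestly upward. Replacing the ring by an open hexyl chain is a larger change than that, so for this assay a step of similar or somewhat greater size in the same direction is expected, though it could also fall within the scatter; the expected step is a 1.5-fold higher number from compound 2 to compound 3 (0.16 log units; within the scatter). Compound 3 is therefore estimated at 35000000 nM, with a range from 9000000 nM to 140000000 nM.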

Compound 3, inhibition constant: 31000000 nM
Estimate against measurement, compound 3: 1.1-fold (0.05 log units) above; measured number inside the range.
By their numbers in this assay, from the lowest: compound 1; then compounds 2 and 3 (each within the scatter of the next).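

In this assay the step from a ring to an open chain is small: hexyl, which has no ring, in place of cyclobutyl gives a 1.3-fold higher number from compound 2 to compound 3 (0.11 log units; within the scatter) and so cannot be told apart from cyclobutyl at this place on a nitrogen on an aromatic ring, something the earlier pair, both carrying rings, could not show. Set against the smallest group of the three, the same chain gives a 2.8-fold higher number from compound 1 to compound 3 (0.45 log units; beyond the scatter) and this modest step lies beyond the scatter, so compound 1 keeps the lowest number while compound 2 and compound 3 stand together above it. No measurement of any property of these groups is at hand that would account for this result.

The compounds shown leave open whether a cyclopentyl or cyclohexyl ring, or a shorter chain such as propyl, would fall with compound 1 or with the other two, and whether a hexyl chain ending in a hydroxyl group or an amine would shift the number at all. They also leave open whether the same small difference between cyclobutyl and hexyl would hold on a different core.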